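A few compounds are considered here, and "the series" means these few. Any claim that something is new, unique, unknown or untested is made for them only; others in the source may bear on it.

Three compounds share one core and differ only in the group on the outer ring. Compound 1 `Fc1ccc(Oc2ccc(/C=N/Nc3nc4ccccc4s3)cc2)cc1` gives 5 in a physicochemical assay for lipophilicity, in phosphate buffer, measured as octanol-water partition, with a stated time of 24 h; on this read-out lower numbers stand for lower lipophilicity and higher numbers for higher lipophilicity. Compound 2 `Clc1ccc(Oc2ccc(/C=N/Nc3nc4ccccc4s3)cc2)cc1` gives 5.6, and compound 3 `O=[N+]([O-])c1ccc(Oc2ccc(/C=N/Nc3nc4ccccc4s3)cc2)cc1` gives 5.1, which leaves compound 3 second highest of the three numbers, close to compound 1 and clearly under compound 2. Two steps join these: a number 0.60 log units higher from compound 1 to compound 2 (beyond the scatter), and a number 0.50 log units lower from compound 2 to compound 3 (beyond the scatter), while a number 0.10 log units higher from compound 1 to compound 3 (within the scatter).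

Compound 4 `Brc1ccc(Oc2ccc(/C=N/Nc3nc4ccccc4s3)cc2)cc1` follows from compound 3 by one change: bromo in place of nitro on an aromatic carbon. Within the data shown here, the step that bears most on this is the one from compound 2 to compound 3, where chloro gave way to nitro and the number fell; the new step runs the other way, taking nitro out and putting in bromo, a single heavy atom with no acceptors, as chloro is. A rise at least as large as that earlier fall is therefore expected, so the step from compound 3 to compound 4 is estimated at a number 0.70 log units higher from compound 3 to compound 4 (beyond the scatter). Compound 4 is expected to give 5.8, within a range from 5.4 to 6.2.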

Compound 4, partition coefficient: 5.5
Estimate against measurement, compound 4: 0.30 log units above; low and high end bracket the measured number.
By their numbers in this assay, from the lowest: compounds 1 and 3 (each within the scatter of the next); then compounds 4 and 2 (each within the scatter of the next).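

At this place on the ring, para to a large group, the four groups now form two pairs in this assay: chloro and bromo on one side, fluoro and nitro on the other. Replacing chloro with bromo leaves the number within the scatter (a number 0.10 log units lower from compound 2 to compound 4 (within the scatter)), whereas bromo stands clear of both nitro (a number 0.40 log units higher from compound 3 to compound 4 (beyond the scatter)) and fluoro (a number 0.50 log units higher from compound 1 to compound 4 (beyond the scatter)). Removing nitro is therefore not what sets the higher pair apart, since compound 1, with fluoro, stays within the scatter of compound 3, and no measurement at hand explains this split.

On these data alone, whether the two pairs hold up with other groups at this place, such as an amine, a carboxylic acid or a longer alkyl chain, remains open. Also open, as far as these compounds go, is whether bromo and chloro would still match if attached elsewhere on the outer ring.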